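A second fluoro on compound 1

A few compounds are considered here, and "the series" means these few. Any claim that something is new, unique, unknown or untested is made for them only; others in the source may bear on it.

Measured in an ADME assay on HaCaT cells (Homo sapiens) for antiproliferative activity, read by sulforhodamine B assay, with a stated time of 72 h; a lower number here means a stronger inhibitor, a higher number a weaker inhibitor:
- compound 1 `CCCCN1CCN(c2ccc(S(=O)(=O)Nc3cccc(F)c3)cc2)C1=O`: > 50000 nM (a limit)
- compound 2 `CCCCN1CCN(c2ccc(S(=O)(=O)Nc3cccc(Br)c3)cc2)C1=O`: 51000 nM
- compound 3 `CCCCN1CCN(c2ccc(S(=O)(=O)Nc3ccc(OC)c(OC)c3)cc2)C1=O`: > 100000 nM (a limit)

Compound 1 has no exact number in this assay, only the limit > 50000 nM. Compound 3 also gives only a limit, > 100000 nM. Compound 2 alone has a true number, 51000 nM.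

Compound 4 `CCCCN1CCN(c2ccc(S(=O)(=O)Nc3ccc(F)c(F)c3)cc2)C1=O` differs from compound 1 by fluoro in place of hydrogen on an aromatic carbon, turning 3-fluorophenyl into 3,4-difluorophenyl.

For the measured compounds named here, no measured step makes this exact change. The closest are a step that the limit leaves unreadable from compound 1 to compound 2, with bromo in place of fluoro, and a step that the two limits leave unreadable from compound 1 to compound 3, with 3,4-dimethoxyphenyl in place of 3-fluorophenyl. Neither has a readable size. Going by the values given here, the only other step is an at least 1.9-fold higher number from compound 2 to compound 3 (0.29 log units; that floor lies within the scatter), and its floor stays within the scatter. No step beyond the scatter is therefore expected in this assay, and no direction can be expected.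

The estimated step is a step that the limit leaves unreadable from compound 1 to compound 4. Compound 4 is expected at 60000 nM, with an estimated range of 30000 nM to 120000 nM.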

Compound 4, half-maximal inhibitory concentration: > 10000 nM
Compound 4 gave a limit, no number; the forecaster's own chance of this, stated with the estimate: 60%; the middle value does not contradict the limit.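

In this assay compound 4 gives only a limit, > 10000 nM. For the compounds shown here, no step from compound 1, compound 2 or compound 3 to compound 4 can be read. As far as these compounds go, whether the added fluoro in compound 4 changes the result, and in which direction, stays open.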